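Propyl in Place of Fluoro: an Expected Value for Compound 4

The compounds below may be only part of what the source reports. "The series", "measured", "known", "first", "only" and "open" are said of these compounds alone.

Of the compounds shown here, three built on one shared core have been tested in a functional assay on HEK293 cells for agonist activity at Glucose-dependent insulinotropic receptor (Homo sapiens), read by a luciferase reporter; a higher number here means that more compound is needed for the effect, a lower number that less compound is needed. Compound 1 `CC#CCn1c(N2CCC[C@@H](N)C2)nc2c1c(=O)n(CCCN1CCN(c3ncc(CC)cn3)CC1)c(=O)n2C` gives 3990 nM. Compound 2 `CC#CCn1c(N2CCC[C@@H](N)C2)nc2c1c(=O)n(CCCN1CCN(c3ncc(C)cn3)CC1)c(=O)n2C` gives 2560 nM, a change of a 1.6-fold lower number from compound 1 to compound 2 (0.19 log units; within the scatter). Compound 3 `CC#CCn1c(N2CCC[C@@H](N)C2)nc2c1c(=O)n(CCCN1CCN(c3ncc(F)cn3)CC1)c(=O)n2C` gives 1410 nM; the step of a 2.8-fold lower number from compound 1 to compound 3 (0.45 log units; beyond the scatter) is the only one that clears the scatter, whereas a 1.8-fold lower number from compound 2 to compound 3 (0.26 log units; within the scatter) does not. Compound 3 thus carries the smallest number of the three, though its separation from compound 2 cannot be relied on.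

Compound 4 `CC#CCn1c(N2CCC[C@@H](N)C2)nc2c1c(=O)n(CCCN1CCN(c3ncc(CCC)cn3)CC1)c(=O)n2C` is not yet measured. It differs from compound 3 by propyl in place of fluoro on an aromatic carbon, the fluoro leaving and a propyl entering on an aromatic carbon of a six-membered aromatic ring with 2 nitrogen, two atoms from the ring nitrogen. For the measured compounds named here, the steps that bear on this change are those at the same place: a 2.8-fold lower number from compound 1 to compound 3 (0.45 log units; beyond the scatter) and a 1.8-fold lower number from compound 2 to compound 3 (0.26 log units; within the scatter), where the longer chain went with the higher number, and the ethyl of compound 1 gave the highest number of all. Propyl extends that chain further, so a step upward in this assay is expected, probably beyond the scatter, with the caution that only one of the earlier steps cleared it. Compound 4 is therefore expected to give 5000 nM, within a range from 2000 nM to 14000 nM, a step of a 3.5-fold higher number from compound 3 to compound 4 (0.55 log units; beyond the scatter).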

Compound 4, half-maximal effective concentration: 1850 nM
The estimate for compound 4 lay 2.7-fold (0.43 log units) above the measured number, outside the stated range (below it).
By their numbers in this assay, from the lowest: compounds 3, 4, 2 and 1 (each within the scatter of the next, the first and the last beyond it).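

In this assay, placing propyl on this aromatic carbon, two atoms from the ring nitrogen, gives a 1.3-fold higher number from compound 3 to compound 4 (0.12 log units; within the scatter), and the comparison with the methyl analogue gives a 1.4-fold lower number from compound 2 to compound 4 (0.14 log units; within the scatter), so neither step can be told apart from the scatter and this position accommodates the three-carbon propyl as readily as the single fluorine atom. For the compounds shown here, the only step involving compound 4 that clears the scatter is a 2.2-fold lower number from compound 1 to compound 4 (0.33 log units; beyond the scatter), which shows that extending ethyl to propyl does not carry the number further up, so compound 4 goes against any reading of these four compounds in which a longer chain at this place always means a higher number. No measurement offered here accounts for this behaviour.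

Going by these compounds, what remains open is whether the difference between the ethyl of compound 1 and the propyl of compound 4 would persist with a longer chain such as butyl, or with a branched group such as isopropyl. It is equally unsettled whether an amine, a carboxylic acid or a methoxy group on this aromatic carbon would move the number beyond the scatter from that of compound 3.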